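Trimming the biphenyl: tolerability of a smaller analogue

The source may report more compounds than this note shows. Statements on the series, on what has been measured and on what is new or still open speak of the compounds shown alone.

Compound 1 `COC(=O)N[C@H](C(=O)NN(CC[C@@](O)(Cc1ccccc1)C(=O)N[C@H]1c2ccccc2C[C@H]1O)Cc1ccc(-c2ccccc2)cc1)C(C)(C)C` was examined in an ADME assay on MT4 cells (Homo sapiens) for cytotoxicity, read by XTT assay, with a stated time of 5 days; a lower number here means that less compound is tolerated, a higher number that more compound is tolerated. In this assay compound 1 gives > 10000 nM, which is a limit of the assay rather than a number. Compound 2 `COC(=O)N[C@H](C(=O)NN(CC[C@@](O)(Cc1ccccc1)C(=O)N[C@H]1c2ccccc2C[C@H]1O)Cc1ccc(-c2ccncc2)cc1)C(C)(C)C` carries pyridin-4-yl in place of phenyl on an aromatic carbon. In this assay compound 2 gives > 10000 nM, again a limit. Among the measured compounds shown here, the only measured step, a step that the two limits leave unreadable from compound 1 to compound 2, cannot be read for size because of the limit of > 10000 nM in this assay, at which 2 of the 2 values shown sit. Compound 3 `COC(=O)N[C@H](C(=O)NN(CC[C@@](O)(Cc1ccccc1)C(=O)N[C@H]1c2ccccc2C[C@H]1O)Cc1ccccc1)C(C)(C)C` is the compound still to be measured. It differs from compound 1 as follows: hydrogen in place of phenyl on an aromatic carbon. For the measured compounds named here, no measured step reports the size of this change; the step from compound 1 to compound 2 touches the same part of the shared core, yet its size stays hidden behind the limit. Compound 3 is expected to sit at the limit once more, with the step that the limit leaves unreadable from compound 1 to compound 3 estimated as none beyond the scatter. Compound 3 is therefore estimated at 20000 nM, within the range 8000 nM to 60000 nM.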

Compound 3, half-maximal cytotoxic concentration: > 10000 nM
Compound 3: a limit, no number; the forecaster's own chance of this, stated with the estimate: 80%; the middle value does not contradict the limit.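

Compound 1, compound 2 and compound 3 all sit at a limit rather than a number, so none of the steps among them can be read for size: the limit of > 10000 nM in this assay, at which 3 of the 3 values shown sit.

The compounds shown leave open whether hydrogen or pyridin-4-yl in place of phenyl on the aromatic carbon changes how much compound is tolerated in this assay at all.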